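Changing the amide side chain of compound 2

This account rests on a few compounds, and the source may have more. Where it says the series, first, only, none or still open, it means among the compounds named here.

In a functional assay on PC-3 cells (Homo sapiens), read by MTT assay, with a stated time of 48 h (on this read-out lower numbers stand for stronger inhibition and higher numbers for weaker inhibition), compound 1 `CCN(CC)CCNC(=O)c1ccc(C(CC)(CC)c2ccc(OCC(=O)C(C)(C)C)c(C)c2)n1CC` gives 30 nM, compound 2 `CCN(CC)CCCNC(=O)c1ccc(C(CC)(CC)c2ccc(OCC(=O)C(C)(C)C)c(C)c2)n1CC` gives 1800 nM and compound 3 `CCN(CC)CCCNC(=O)c1ccc(C(CC)(CC)c2ccc(OCC(O)C(C)(C)C)c(C)c2)n1CC` gives 2500 nM. Compound 2 thus sits with compound 3 at the high end of the three numbers, far from compound 1.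

Compound 4 `CCn1c(C(=O)N(C)CC(=O)O)ccc1C(CC)(CC)c1ccc(OCC(=O)C(C)(C)C)c(C)c1` differs from compound 2 as follows: (carboxymethyl)(methyl)amino in place of (3-(diethylamino)propyl)amino on a carbonyl carbon. This places (carboxymethyl)(methyl)amino in place of (3-(diethylamino)propyl)amino on a carbonyl carbon. Going by the values given here, two measured steps bear on this change. The one on the amide side chain, a 60-fold higher number from compound 1 to compound 2 (1.78 log units; beyond the scatter), is large and shows that the number can move strongly with changes there. The other, a 1.4-fold higher number from compound 2 to compound 3 (0.14 log units; within the scatter), lies elsewhere in the molecule and says little about this change.

Among the compounds with values here, no measured compound carries the incoming group, so the direction remains uncertain. A sizeable move towards a lower number is expected, given the high starting point. The expected change is a 4.5-fold lower number from compound 2 to compound 4 (0.65 log units; beyond the scatter). For compound 4 the estimate is 400 nM, with an expected range from 40 nM to 4000 nM.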

Compound 4, half-maximal inhibitory concentration: 18400 nM
The estimate for compound 4 lay 46-fold (1.66 log units) below the measured number; measured number above the stated range.
By their numbers in this assay, from the lowest: compound 1; then compounds 2 and 3 (each within the scatter of the next); then compound 4.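

Placing (carboxymethyl)(methyl)amino in place of (3-(diethylamino)propyl)amino on the carbonyl carbon gives a 10-fold higher number from compound 2 to compound 4 (1.01 log units; beyond the scatter) and shows that the number at this position can still rise from an already high starting point. Set against the (2-(diethylamino)ethyl)amino group of compound 1, the same incoming group gives a 610-fold higher number from compound 1 to compound 4 (2.79 log units; beyond the scatter) as the largest step among these compounds. No data shown here account for either step.

The whole side chain changes in one move, so the share of the carboxylic acid, the methyl on the amide nitrogen and the loss of the diethylamino group remains unresolved. Open too, as far as these compounds go, is how a (carboxymethyl)amino group without that methyl, or the methyl ester of the acid, would read out.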